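The source may hold more compounds than are shown below. What is called first, only, known or untested is meant among the compounds shown, and "the series" means these compounds.

Working notes on the series. Compound 1 `CCCC(CCC)C(=O)OC[C@H]1O[C@@H](n2cnc3c(N)ncnc32)[C@H](OC(=O)C(CCC)CCC)[C@]1(C)O` carries the (1-propylbutyl)carbonyl group on two oxygens of the shared core; in a functional assay on HL-60 cells (Homo sapiens) for inhibition, read by MTT assay, with a stated time of 48 h (on this read-out higher numbers stand for weaker inhibition and lower numbers for stronger inhibition), compound 1 gives 16300 nM, the lowest of the two numbers in hand. Compound 2 `CCCC(CCC)C(=O)O[C@H]1[C@H](n2cnc3c(N)ncnc32)O[C@H](CO)[C@@]1(C)O` keeps one of the two esters and gives 650000 nM in this assay. Compound 3 `CCCC(CCC)C(=O)Nc1ncnc2c1ncn2[C@@H]1O[C@H](COC(=O)C(CCC)CCC)[C@@](C)(O)[C@H]1OC(=O)C(CCC)CCC`, with a third (1-propylbutyl)carbonyl on the ring nitrogen, returned "nd(insoluble)" (no result reported) in this assay, so it adds nothing to the comparison. Going by the values given here, the only measured step, a 40-fold higher number from compound 1 to compound 2 (1.60 log units; beyond the scatter), shows that losing one (1-propylbutyl)carbonyl from an oxygen on a saturated carbon costs a great deal of inhibition.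

Compound 4 `CCCC(CCC)C(=O)OC[C@H]1O[C@@H](n2cnc3c(N)ncnc32)[C@H](O)[C@]1(C)O` is the other single-ester product of compound 1: hydrogen in place of (1-propylbutyl)carbonyl on an oxygen on a saturated carbon. Among the compounds with values here, in words the change matches the step to compound 2, but it falls on the other oxygen, the one on a saturated ring carbon, and no measured pair tells whether that oxygen behaves the same. Within the data shown here, the step to compound 2 is the only guide and points to a clearly weaker inhibitor. The expectation for compound 4 is therefore a step of a 9.2-fold higher number from compound 1 to compound 4 (0.96 log units; beyond the scatter), taken somewhat smaller than the measured one because a 40-fold higher number from compound 1 to compound 2 (1.60 log units; beyond the scatter) concerns a different oxygen. Compound 4 is estimated at 150000 nM, within 40000 nM to 600000 nM.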

Compound 4, half-maximal inhibitory concentration: 67100 nM
Compound 4: the middle estimate sits 2.2-fold (0.35 log units) above what was measured; measured number inside the range.
By their numbers in this assay, from the lowest: compound 1; then compound 4; then compound 2.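

In this assay, hydrogen in place of (1-propylbutyl)carbonyl on the oxygen on a saturated carbon whose other neighbours are saturated ring carbon gives a 4.1-fold higher number from compound 1 to compound 4 (0.61 log units; beyond the scatter), so removal at this position also goes beyond the scatter, and this step is rated modest. Set beside a 40-fold higher number from compound 1 to compound 2 (1.60 log units; beyond the scatter), rated large, it shows that both single-ester compounds lie above compound 1, with neither compound going against that pattern, although the two oxygens do not give steps of the same rated size; with only these compounds in hand, the pattern reaches no further than compound 1, compound 2 and compound 4. Nothing on hand gives a measured reason for either step.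

Still open, from the compounds shown here alone, is whether the (1-propylbutyl)carbonyl group itself matters at this oxygen, or whether an acetyl group, a longer chain or an amine-bearing ester there would keep the number of compound 1. Also open, going by these compounds, are the compound with hydroxy on both oxygens, which would show the effect of losing both esters together, and the effect of the third (1-propylbutyl)carbonyl on the ring nitrogen, since compound 3 gives no number.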